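This account rests on a few compounds, and the source may have more. Where it says the series, first, only, none or still open, it means among the compounds named here.

Working notes on the series in an assay on membranes from CHO cells for displacement of a labelled ligand from adenosine receptor A1 (Homo sapiens), read by scintillation counting, with a stated time of 60 min, tested at 1 uM; on this read-out higher numbers stand for more inhibition at the one concentration tested (going by the name of the read-out) and lower numbers for less inhibition. Compound 1 `COC(=O)C1=C(C)NC(=S)NC1c1ccoc1` gives 25% in this assay. Compound 2 `COC(=O)C1=C(C)NC(=S)NC1c1cccs1` gives 1%, and compound 3 `CC1=C(C(=O)OC(C)(C)C)C(c2cccs2)NC(=S)N1` gives 22%. Compound 2 therefore stands lowest of the three numbers at hand: compound 3 is nearest and compound 1 furthest, both separated from it beyond the scatter. The step of a number 24 percentage points lower from compound 1 to compound 2 (beyond the scatter) is a modest loss that comes with a change of the ring on the saturated ring carbon; the step of a number 21 percentage points higher from compound 2 to compound 3 (beyond the scatter) is a modest gain that comes with a change of the ester group.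

Compound 4 `COC(=O)C1=C(C)NC(=S)NC1c1ccsc1` has not been measured in this assay. The change from compound 2 is thiophen-3-yl in place of thiophen-2-yl on a saturated ring carbon. Going by the values given here, of the two measured steps, only the one from compound 1 to compound 2 touches the same place, and there both the ring heteroatom and the point of attachment changed at once, so its modest size is read as only a loose guide. The step from compound 2 to compound 3 does not bear on the ring change. On this basis a modest gain from compound 2 is expected for compound 4, a number 14 percentage points higher from compound 2 to compound 4 (beyond the scatter), not a large one. Compound 4 is estimated at 15%, within a range of 0% to 35%.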

Compound 4, a percentage reported as inhibition, at one concentration (the size of the read-out at that concentration, not a potency): 3%
Beside the measured number, compound 4's estimate is 12 percentage points above it, and the stated range covers the measured number.
By their numbers in this assay, from the lowest: compounds 2 and 4 (each within the scatter of the next); then compounds 3 and 1 (each within the scatter of the next).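

Thiophen-3-yl in place of thiophen-2-yl on the saturated ring carbon gives a number 2 percentage points higher from compound 2 to compound 4 (within the scatter) in this assay, so with the ring kept the same, the point of attachment shows no effect that this read-out can resolve. With the attachment held constant, thiophen-3-yl in place of furan-3-yl gives a number 22 percentage points lower from compound 1 to compound 4 (beyond the scatter), which separates two changes that were combined in a number 24 percentage points lower from compound 1 to compound 2 (beyond the scatter) and ties the loss among these three compounds to the ring heteroatom, sulfur in place of oxygen, not to the point of attachment. No measured evidence is at hand to explain this difference between the two rings.

Still open, on these data alone, is whether the gain seen in a number 21 percentage points higher from compound 2 to compound 3 (beyond the scatter) with tert-butyl in place of methyl on the ester oxygen carries over to the thiophen-3-yl and furan-3-yl compounds. Also open, as far as these compounds go, is how furan-2-yl, phenyl, pyridin-3-yl or a ring bearing an amine would read on the same saturated ring carbon.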